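Aryl-to-cyclohexyl swap on the shared core

This account rests on a few compounds, and the source may have more. Where it says the series, first, only, none or still open, it means among the compounds named here.

Measured so far:
- compound 1 `Cc1ccc(C(Nc2ccc(C(=O)O)cc2)c2ccc3cccnc3c2O)cc1` — an assay on isolated protein for inhibition of CAAX prenyl protease 2 (Homo sapiens), with stated times of 60 s and 60 min (on this read-out higher numbers stand for weaker inhibition and lower numbers for stronger inhibition), 7100 nM
- compound 2 `Cc1ccc(NC(c2ccccc2)c2ccc3cccnc3c2O)cc1` — this assay 8800 nM

Compound 1 gives the lowest of the two numbers shown; its nearest neighbour is compound 2, and the gap between the two lies within the scatter, so no order between them can be claimed.

Compound 3 `O=C(O)c1ccc(NC(c2ccc3cccnc3c2O)C2CCCCC2)cc1` is not yet measured. It differs from compound 1 as follows: cyclohexyl in place of 4-methylphenyl on a saturated chain carbon bound to an aromatic carbon and a nitrogen on an aromatic ring. Within the data shown here, no step between measured compounds covers this kind of change, so nothing measured here tells how the read-out responds to it. Without such a precedent the expectation is a small step, in the direction of a somewhat higher number, likely within or only just beyond the scatter: the step from compound 1 to compound 3 is expected to be a 1.3-fold higher number from compound 1 to compound 3 (0.13 log units; within the scatter). For compound 3 the estimate in this assay is 9500 nM, with a range from 3000 nM to 30000 nM.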

Compound 3, half-maximal inhibitory concentration: 9800 nM
The estimate for compound 3 lay 1.0-fold (0.01 log units) below the measured number, and the stated range covers the measured number.
By their numbers in this assay, from the lowest: compounds 1, 2 and 3 (each within the scatter of the next).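

In this assay cyclohexyl in place of 4-methylphenyl on the saturated chain carbon gives a 1.4-fold higher number from compound 1 to compound 3 (0.14 log units; within the scatter) and provides the first step read at this position. The step stays within the scatter, so in this pair the read-out does not separate the six-membered aromatic ring of carbon only from the six-membered non-aromatic ring of carbon only, and an aromatic ring here is not needed for a value in this range. No measurement on hand explains this result.

As far as these compounds go, this rests on one pair, so it remains open whether the same swap behaves alike on a core with other substituents. Also open, from the compounds shown here alone, is whether a much smaller group such as methyl, a longer alkyl chain, or a ring bearing an amine at this carbon would move the number beyond the scatter.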